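Three Compounds and a Benzyl Swap

This account rests on a few compounds, and the source may have more. Where it says the series, first, only, none or still open, it means among the compounds named here.

Values measured in an ADME assay for permeability, using PAMPA, with a stated time of 30 min, at pH 7.4 (a higher number here means that the compound crosses the layer faster, a lower number that the compound crosses the layer more slowly), are:
- compound 1 `COc1cccc(CNCCCNc2ccnc3cc(Oc4ccccc4)ccc23)c1O` gives 317 10^-6 cm/s
- compound 2 `COc1cccc(CNCCCNc2ccnc3cc(-c4ccc(C(C)(C)C)cc4)ccc23)c1O` gives 237 10^-6 cm/s
- compound 3 `COc1cccc(Oc2ccc3c(NCCCNCc4cccc(OC)c4O)ccnc3c2)c1` gives 317 10^-6 cm/s

Compound 3 stands level with compound 1 at the digits shown, and compound 2 lies within the scatter of both. Compound 4 `COc1cccc(CNCCCNc2ccnc3cc(Cc4cccc(C(F)(F)F)c4)ccc23)c1O` carries 3-(trifluoromethyl)benzyl in place of 3-methoxyphenoxy on an aromatic carbon. Two measured steps exchanged the group at such a carbon, a 1.3-fold lower number from compound 1 to compound 2 (0.13 log units; within the scatter) and a 1.3-fold higher number from compound 2 to compound 3 (0.13 log units; within the scatter), while the methoxy addition gave no change at the digits printed from compound 1 to compound 3 (within the scatter). None of these left the scatter, although neither exchange brought in this benzyl group. No change beyond the scatter is therefore expected, the estimate being a 1.1-fold lower number from compound 3 to compound 4 (0.05 log units; within the scatter) in this assay. For compound 4 the estimated value is 280 10^-6 cm/s (expected range 140 10^-6 cm/s to 480 10^-6 cm/s).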

Compound 4, apparent permeability: 23 10^-6 cm/s
The estimate for compound 4 lay 12-fold (1.09 log units) above the measured number, and the stated range ends above it.
By their numbers in this assay, from the lowest: compound 4; then compounds 2, 1 and 3 (each within the scatter of the next).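

In this assay this position proves sensitive to what it carries: 3-(trifluoromethyl)benzyl gives a 14-fold lower number from compound 3 to compound 4 (1.14 log units; beyond the scatter) and a 14-fold lower number from compound 1 to compound 4 (1.14 log units; beyond the scatter) and also a 10-fold lower number from compound 2 to compound 4 (1.01 log units; beyond the scatter) while the earlier exchanges stayed within the scatter. The step is large from all three compounds, whichever group leaves. Nothing shown gives a reason for this.

The change swaps the oxygen link for a carbon link and methoxy for trifluoromethyl in one move. Plain benzyl or 3-(trifluoromethyl)phenoxy at this carbon would show which part carries the drop.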